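A few compounds are considered here, and "the series" means these few. Any claim that something is new, unique, unknown or untested is made for them only; others in the source may bear on it.

Of the compounds shown here, three have so far been measured in a functional assay on HL-60 cells (Homo sapiens) for cytotoxicity, read by luminescence and CellTiter-Glo, with a stated time of 3 days; on this read-out lower numbers stand for stronger inhibition and higher numbers for weaker inhibition. Compound 1 `O=C(Nc1cc(C(F)(F)F)cc(C(F)(F)F)c1)c1cc(Cl)c(-c2ccccc2)cc1O` gives 790 nM in this assay. Compound 2 `N#Cc1ccc(NC(=O)c2cc(-c3ccncc3)ccc2O)cc1` gives 5410 nM, the higher of the two numbers, and the gap down to compound 1 lies beyond the usual scatter. Compound 3 `COc1cccc(C(=O)Nc2ccc(C#N)cc2)c1O` gives > 10000 nM in this assay, which is a limit of the measurement rather than a number. Compound 4 `COc1ccc(O)c(C(=O)Nc2ccc(C#N)cc2)c1` has not yet been measured; it differs from compound 2 by methoxy in place of pyridin-4-yl on an aromatic carbon. The expected direction is a higher number, meaning weaker inhibition, and the step from compound 2 to compound 4 is expected to be a 1.7-fold higher number from compound 2 to compound 4 (0.22 log units; within the scatter). This expectation rests on compound 3, which also carries a methoxy and sits at the limit of > 10000 nM in this assay, at which 1 of the 3 values shown sits. Compound 4 is therefore expected to give about 9000 nM, somewhere between 3000 nM and 30000 nM.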

Compound 4, half-maximal inhibitory concentration: > 10000 nM
Compound 4: only a limit was reported (the forecaster's own chance of this, stated with the estimate: 45%); at least 1.1-fold (0.04 log units) between middle value and limit.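

At this position, para to a hydroxy group, methoxy in place of pyridin-4-yl gives an at least 1.8-fold higher number from compound 2 to compound 4 (0.26 log units; that floor lies within the scatter) in this assay. On these data alone, compound 4 reports only a limit, so the true size of this step stays unknown and it may be larger than that floor. Compound 4 now shares that limit with compound 3, the other methoxy compound: the limit of > 10000 nM in this assay, at which 2 of the 4 values shown sit.

What the compounds leave open is whether an amine, a morpholine ring or a carboxylic acid at this position would give a number under the limit, and so whether a ring is needed here at all.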